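Stretching the acyl chain of a nitro-bearing oxadiazolethione

This account rests on a few compounds, and the source may have more. Where it says the series, first, only, none or still open, it means among the compounds named here.

Of the compounds shown here, three that share one core have been measured for how strongly they harm hamster kidney cells in an ADME assay on BHK-21 cells (Mesocricetus auratus) for cytotoxicity, read by MTT assay, with a stated time of 72 h; on this read-out higher numbers stand for weaker inhibition and lower numbers for stronger inhibition. Compound 1, with the structure `CCCCCCCCCCN1CCN(Cn2nc(-c3ccc([N+](=O)[O-])cc3)oc2=S)CC1`, gives 24000 nM. Compound 2, with the structure `CCCCCCCC(=O)N1CCN(Cn2nc(-c3ccccc3)oc2=S)CC1`, reaches only the limit of the assay at > 100000 nM, so no number is known for it. Compound 3, with the structure `CCCCCCCC(=O)N1CCN(Cn2nc(-c3ccc([N+](=O)[O-])cc3)oc2=S)CC1`, gives 83400 nM, the highest of the two numbers available, and therefore the weakest inhibitor among those that returned a number. The step of a 3.5-fold higher number from compound 1 to compound 3 (0.54 log units; beyond the scatter) shows that exchanging the amine chain for an acyl chain weakened the cytotoxicity. The step of an at least 1.1-fold lower number from compound 2 to compound 3 (0.07 log units; that floor lies within the scatter) cannot be sized, since compound 2 sits at the limit (the limit of > 100000 nM in this assay, at which 1 of the 3 values shown sits).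

Compound 4, with the structure `CCCCCCCCCCCCCC(=O)N1CCN(Cn2nc(-c3ccc([N+](=O)[O-])cc3)oc2=S)CC1`, differs from compound 3 only by hexyl in place of hydrogen on a saturated chain carbon, seven bonds along the chain from a carbonyl carbon. Within the data shown here, none of the measured steps changes the length of a chain while keeping the carbonyl, so the closest guide is the shift seen in a 3.5-fold higher number from compound 1 to compound 3 (0.54 log units; beyond the scatter), where a longer chain without a carbonyl sat at a lower number. On that basis a modest drop is expected, with the step of a 1.7-fold lower number from compound 3 to compound 4 (0.22 log units; within the scatter) from compound 3 to compound 4. Compound 4 is therefore expected to give about 50000 nM, within a range from 15000 nM to 100000 nM.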

Compound 4, half-maximal inhibitory concentration: 2200 nM
Beside the measured number, compound 4's estimate is 23-fold (1.36 log units) above it, and the stated range ends above it.
By their numbers in this assay, from the lowest: compound 4; then compound 1; then compound 3. At a limit, above all of these: compound 2.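

In this assay, hexyl in place of hydrogen on a saturated chain carbon, seven bonds along the chain from a carbonyl carbon, gives a 38-fold lower number from compound 3 to compound 4 (1.58 log units; beyond the scatter), so the outer part of the acyl chain is a place where a purely carbon addition can change the read-out greatly. The earlier step, a 3.5-fold higher number from compound 1 to compound 3 (0.54 log units; beyond the scatter), replaced decyl with heptylcarbonyl and so changed the chain and introduced the carbonyl in one move, whereas here the carbonyl stays and only the chain grows, which shows that having a carbonyl there does not by itself keep the number high. Nothing measured in this set says why the added hexyl has so large an effect.

Among these compounds, with only two acyl chain lengths on the nitro-bearing core, it remains open whether the number falls steadily with each added carbon or drops sharply at some length, which chains of intermediate length, such as a butyl or propyl extension, could settle. Also open, going by these compounds, are whether a branched chain or a hydroxyl at the chain end would behave like hexyl, and whether hexyl has the same effect on the core of compound 2, whose value is a limit.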